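Removing the Pyrrolidine Ring from a Potent Receptor Binder

The source may hold more compounds than are shown below. What is called first, only, known or untested is meant among the compounds shown, and "the series" means these compounds.

Of the compounds shown here, two have been tested in an assay on MDA-MB-231 cells for displacement of a labelled ligand from C-X-C chemokine receptor type 4 (Homo sapiens); a lower number here means that less compound is needed, a higher number that more compound is needed for the effect. Compound 1 `c1cnc(NCc2ccc(CNc3ccccc3N3CCCC3)cc2)nc1` gives 100 nM in this assay. Compound 2 `c1cnc(NCc2ccc(CNc3ccc(N4CCCC4)cc3)cc2)nc1` gives 1 nM in this assay, the lowest of the two numbers: compound 1 needs a higher concentration, and the gap between the two lies well beyond the scatter of repeated measurements. The two compounds share the same core and differ only in where the pyrrolidin-1-yl group sits on the outer ring.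

Compound 3 `c1ccc(NCc2ccc(CNc3ncccn3)cc2)cc1` has not yet been measured. Compared with compound 2, the change is hydrogen in place of pyrrolidin-1-yl on an aromatic carbon. The pyrrolidin-1-yl group leaves, a hydrogen enters, and nothing else in the structure moves.

Within the data shown here, no measured pair shows exactly this kind of change, so the expectation rests on the fact that the pyrrolidin-1-yl group is the only feature that separates the two measured compounds. Losing it altogether is expected to cost potency, so the estimated step of a 100-fold higher number from compound 2 to compound 3 (2.00 log units; beyond the scatter) goes toward a higher number in this assay, clearly beyond the scatter. Compound 3 is therefore estimated at 100 nM, with a plausible range from 10 nM to 2000 nM.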

Compound 3, effective concentration (reported as EC, without a stated level of effect): 10 nM
Beside the measured number, compound 3's estimate is 10-fold (1.00 log units) above it, within the range that was stated.
By their numbers in this assay, from the lowest: compound 2; then compound 3; then compound 1.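

Hydrogen now gives a reference point that the first two compounds lacked. In this assay the exchange of pyrrolidin-1-yl for hydrogen at the place para to a large group brings a 10-fold higher number from compound 2 to compound 3 (1.00 log units; beyond the scatter) and so the group goes with a lower number at this place, although compound 3 remains a low-nanomolar binder without it. Read from the other compound, the same exchange brings a 10-fold lower number from compound 1 to compound 3 (1.00 log units; beyond the scatter) and so pyrrolidin-1-yl at its place in compound 1 goes with a higher number than hydrogen does, which means that the same group moves the number in opposite directions at its two places on the outer ring, and no measurement shown here accounts for either direction.

The compounds shown leave open whether the lower number at the para place goes with the whole ring or only with its attached nitrogen, a question that a simple dimethylamino group or a morpholine ring at that place could help to answer. They also leave open how any group behaves at the remaining places on the outer ring, so two placements are all that can be compared.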